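Halogen swap on a sulfonamide series against MCF7 cells

The source may report more compounds than this note shows. Statements on the series, on what has been measured and on what is new or still open speak of the compounds shown alone.

Measured so far:
Compound 1, `O=C(NS(=O)(=O)c1ccc(Br)cc1)c1cccnc1Cl`, 11400 nM
Compound 2, `O=C(NS(=O)(=O)c1ccc(Cl)cc1)c1cccnc1Cl`, 10200 nM
Compound 3, `O=C(NS(=O)(=O)c1ccc(Br)cc1)c1ccc(Cl)nc1`, 9050 nM

Three compounds were tested in a functional assay on MCF7 cells (Homo sapiens) for antiproliferative activity, read by MTT assay, with a stated time of 48 h; on this read-out higher numbers stand for weaker inhibition and lower numbers for stronger inhibition. Compound 1 gives 11400 nM, compound 2 gives 10200 nM and compound 3 gives 9050 nM. All three numbers sit within the scatter of one another, so no order among them can be read from these data.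

Compound 1 and compound 2 differ in one place, (chloro in place of bromo on an aromatic carbon), and that change made a step of a 1.1-fold lower number from compound 1 to compound 2 (0.05 log units; within the scatter). Compound 3 shares its atoms with compound 1 but joins them differently; the difference between the two cores is not broken down here.

Compound 4, `O=C(NS(=O)(=O)c1ccc(Cl)cc1)c1ccc(Cl)nc1`, has not been measured. It differs from compound 3 by chloro in place of bromo on an aromatic carbon, the same change as from compound 1 to compound 2. Because the earlier step was a 1.1-fold lower number from compound 1 to compound 2 (0.05 log units; within the scatter), the step from compound 3 to compound 4 is expected to be about as small, a 1.1-fold lower number from compound 3 to compound 4 (0.04 log units; within the scatter). Compound 4 is therefore estimated at 8300 nM, expected to fall between 4000 nM and 17000 nM.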

Compound 4, half-maximal inhibitory concentration: 8070 nM
Compound 4: the middle estimate sits 1.0-fold (0.01 log units) above what was measured, and the stated range covers the measured number.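

In this assay, chloro in place of bromo on the core of compound 3 gave a step of a 1.1-fold lower number from compound 3 to compound 4 (0.05 log units; within the scatter), so on this second core too the swap left no readable mark on the number. Set side by side, the two steps agree: the same change on two cores in this assay, a 1.1-fold lower number (0.05 log units; within the scatter) from compound 1 to compound 2 and a 1.1-fold lower number (0.05 log units; within the scatter) from compound 3 to compound 4, 1.0-fold (0.00 log units) apart, within the scatter of two such steps. Among the compounds shown here, the swap therefore carries from one core to the other with a step of the same small size, but this agreement shows only that the change does little on both cores; it does not show that the same would hold on any further core, nor can steps this small reveal any real difference between the two cores.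

The compounds shown carry only bromo or chloro on the aromatic carbon para to a large group. Going by these compounds, what an amine, a carboxylic acid or a longer chain would do at that place remains open, as does whether any such group would behave alike on both cores.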